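From a benzyl amide to a phenyl amide, without a baseline

The compounds below may be only part of what the source reports. "The series", "measured", "known", "first", "only" and "open" are said of these compounds alone.

Compound 3 (`CS(=O)(=O)N1C[C@H](C(=O)NCc2ccc(Cl)cc2)[C@@H](C(=O)Nc2ccc(-n3ccccc3=O)cc2F)C1`) offers no number to start from: in a physicochemical assay for lipophilicity, at pH 7.4 (a higher number here means a more lipophilic compound, a lower number a more polar compound), compound 3 stands as "not determined" (no result reported). Two relatives on the same core do have values. In this assay compound 1 (`CS(=O)(=O)N1C[C@H](C(=O)Nc2ccc(Cl)cn2)[C@@H](C(=O)Nc2ccc(-n3ccccc3=O)cc2F)C1`) gives 1.46, and compound 2 (`COc1ccc(NC(=O)[C@H]2CN(S(C)(=O)=O)C[C@@H]2C(=O)Nc2ccc(-n3ccccc3=O)cc2F)cc1Cl`) gives 1.9.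

The move to compound 4 (`CS(=O)(=O)N1C[C@H](C(=O)Nc2ccc(Cl)c(F)c2)[C@@H](C(=O)Nc2ccc(-n3ccccc3=O)cc2F)C1`) puts 4-chloro-3-fluorophenyl in place of 4-chlorobenzyl on an amide-type nitrogen.

Among the measured compounds shown here, only one measured step bears on this, and only indirectly. It is a number 0.44 log units higher from compound 1 to compound 2 (beyond the scatter), a modest change beyond the scatter, with 3-chloro-4-methoxyphenyl in place of 5-chloropyridin-2-yl on an amide-type nitrogen. For the measured compounds named here, no measured step removes a 4-chlorobenzyl group, and compound 3 has no number, so no size or direction can be expected for the step itself. The expectation therefore rests on the neighbouring values alone. Compound 4 carries a substituted phenyl on that nitrogen, as compound 2 does at 1.9, so a value in that region is expected rather than one nearer compound 1 at 1.46.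

The estimated value for compound 4 is 2.1, with an expected range from 1.7 to 2.5.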

Compound 4, distribution coefficient: 2.37
Compound 4: middle estimate off by 0.27 log units, on the low side; the range from low to high includes it.
By their numbers in this assay, from the lowest: compound 1; then compound 2; then compound 4.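

In this assay, among the compounds shown here, the result shows that this amide-type nitrogen still separates two substituted phenyl groups: with 4-chloro-3-fluorophenyl in place of 3-chloro-4-methoxyphenyl, the read-out gives a number 0.47 log units higher from compound 2 to compound 4 (beyond the scatter), a difference the earlier compounds could not show. Measured against 5-chloropyridin-2-yl, the same group gives a number 0.91 log units higher from compound 1 to compound 4 (beyond the scatter), and the three groups with values now fall in one order at this position, with 5-chloropyridin-2-yl lowest and 4-chloro-3-fluorophenyl highest. No measurement or other evidence shown here explains this order.

From the compounds shown here alone, the 4-chlorobenzyl side stays open: compound 3 has no result, and the step from it to compound 4 cannot be read. Also open, going by these compounds, is how a plain 4-chlorophenyl group would read on this nitrogen, which would set the fluorine of compound 4 apart from its chlorine, and how the same position would read with a group of another kind, such as an amine, a carboxylic acid or a longer chain.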